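The source may hold more compounds than are shown below. What is called first, only, known or untested is meant among the compounds shown, and "the series" means these compounds.

Measured so far:
Compound 1, `Cc1nnc(N2CCC(C(=O)N3N=CC[C@H]3c3cc(F)cc(F)c3)CC2)o1`, in an ADME assay on the whole organism (Rattus norvegicus) for pharmacokinetics, at a dose of 2 mg/kg by the oral route (on this read-out higher numbers stand for higher exposure at the dose given and lower numbers for lower exposure), gives 2930 nM.
Compound 2, `O=C(C1CCOCC1)N1N=CCC1c1ccccc1`, in this assay gives 368 nM.
Compound 3, `CC(C)(C)C(=O)N1N=CCC1c1cccnc1`, in this assay gives 1560 nM.

Compound 1 gives the highest of the three numbers. Its gap to compound 3 lies within the usual scatter of repeated measurements, so those two cannot be told apart; its gap to compound 2 lies beyond the scatter, so compound 1 clearly shows the higher exposure of that pair.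

Compound 4, `N#Cc1cnc(N2CCC(C(=O)N3N=CC[C@H]3c3cc(F)cc(F)c3)CC2)cn1`, is not yet measured. It differs from compound 1 in one place: 5-cyanopyrazin-2-yl in place of 5-methyl-1,3,4-oxadiazol-2-yl on an amine nitrogen in a ring.

For the measured compounds named here, no pair of measured compounds shows a step of this kind, so nothing in the data says how such an exchange moves exposure. The expectation is a step from compound 1 to compound 4 of about a 1.5-fold lower number from compound 1 to compound 4 (0.17 log units; within the scatter), that is, none beyond the scatter. Compound 4 is thus estimated at 2000 nM, within a range of 600 nM to 6500 nM.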

Compound 4, maximal plasma concentration: 184 nM
Compound 4: middle estimate off by 11-fold (1.04 log units), on the high side, outside the stated range (below it).
By their numbers in this assay, from the lowest: compounds 4 and 2 (each within the scatter of the next); then compounds 3 and 1 (each within the scatter of the next).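

In this assay the exchange of 5-methyl-1,3,4-oxadiazol-2-yl for 5-cyanopyrazin-2-yl gives a 16-fold lower number from compound 1 to compound 4 (1.20 log units; beyond the scatter) and so shows that the group on this amine nitrogen can strongly change exposure. Both groups have the same count of hydrogen-bond acceptors and no donors, so those counts do not separate this pair. No measurement here explains the drop.

On these data alone, it remains open whether the drop goes with the six-membered aromatic ring or with its cyano group. As far as these compounds go, how an amine or a carboxylic acid in place of that cyano group would behave also remains open.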